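Pyridin-3-yl in Place of Phenyl: Does Stability Hold?

The source may report more compounds than this note shows. Statements on the series, on what has been measured and on what is new or still open speak of the compounds shown alone.

In an unclassified assay for metabolic stability, read by HPLC, with a stated time of 5 min (on this read-out lower numbers stand for a less stable compound and higher numbers for a more stable compound), compound 1 (`c1ccc(/N=N/c2ccc(N3CCN([C@H]4CC[C@@H](c5ccccc5)CC4)CC3)cn2)cc1`) gives 88%, and compound 2 (`c1ccc(/N=N/c2ccc(N3CCN([C@H]4CC[C@@H](c5ccccc5)CC4)CC3)cc2)cc1`) gives 93%. Going by the values given here, these two values lie within the usual scatter of each other, so compound 2 stands level with the only other number available. Compound 3 (`c1ccc([C@H]2CC[C@@H](N3CCN(c4ccc(/N=N/c5cccnc5)cc4)CC3)CC2)cc1`) differs from compound 2 in one place: pyridin-3-yl in place of phenyl on a double-bonded nitrogen. In words, pyridin-3-yl stands in place of phenyl on a double-bonded nitrogen. Among the compounds with values here, no pair of measured compounds shows this swap, so the data offer no direct guide to its effect, and any forecast remains uncertain. At most a small drop is expected, with nothing beyond the scatter, and the estimated step is a number 4 percentage points lower from compound 2 to compound 3 (within the scatter). Compound 3 is expected at 89%, with an estimated range from 76% to 97%.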

Compound 3, percent of the compound remaining in the unclassified assay: 100%
Estimate against measurement, compound 3: 11 percentage points below; measured number above the stated range.
By their numbers in the unclassified assay, from the lowest: compounds 1, 2 and 3 (each within the scatter of the next, the first and the last beyond it).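

This swap can now be read directly: in the unclassified assay compound 2 gives 93% and compound 3 gives 100%, so pyridin-3-yl in place of phenyl on a double-bonded nitrogen gives a number 7 percentage points higher from compound 2 to compound 3 (within the scatter) and so shows no loss beyond the scatter. In a physicochemical assay for metabolic stability, read by HPLC, with a stated time of 48 h, tested at 500 uM (a lower number here means that less of the compound is left, a higher number that more of the compound is left), compound 2 gives 93% and compound 3 gives 100%; the same pair gives a number 7 percentage points higher from compound 2 to compound 3 (within the scatter) and leaves the same picture, so at this position the two read-outs agree that a ring with one hetero atom is tolerated as well as the all-carbon ring. No supporting measurement explains why the two compounds stand level.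

This single pair cannot show a general rule for the position. Going by these compounds, it remains open whether stability would also hold with a carboxylic acid or an amine on the ring at this double-bonded nitrogen.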